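Oxime Pyridinium and Imidazolium Ethers: One Change, Two Cores

The source may hold more compounds than are shown below. What is called first, only, known or untested is meant among the compounds shown, and "the series" means these compounds.

Compound 1, `C#CCCCC[n+]1ccn(C(C)(C)C)c1/C=N/O`, gives -1.42 in a physicochemical assay for lipophilicity; on this read-out higher numbers stand for higher lipophilicity and lower numbers for lower lipophilicity.
Compound 2, `C#CCCOC[n+]1ccn(C(C)(C)C)c1/C=N/O`, gives -1.84 in this assay.
Compound 3, `C#CCCOC[n+]1ccc(/C=N/O)cc1`, gives -2.72 in this assay.

Compound 3 stands lowest of the three measured compounds, below compound 2 and further below compound 1, both gaps beyond the scatter. The difference between the core of compound 3 and the core of compound 2 is not broken down here.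

Within the core of compound 2, one change is measured: pent-4-yn-1-yl in place of (but-3-yn-1-yl)oxy on a saturated chain carbon bound to an aromatic nitrogen. It gave a number 0.42 log units higher from compound 2 to compound 1 (beyond the scatter).

Compound 4, `C#CCCCC[n+]1ccc(/C=N/O)cc1`, is not yet measured. It carries the same change, now on the core of compound 3: pent-4-yn-1-yl in place of (but-3-yn-1-yl)oxy on a saturated chain carbon bound to an aromatic nitrogen. Both changes sit at the same place, a saturated chain carbon bound to an aromatic nitrogen.

Compound 4 is expected to show a number 0.42 log units higher from compound 3 to compound 4 (beyond the scatter) in this assay, a step of about the same size as the earlier one, because that earlier step gave a number 0.42 log units higher from compound 2 to compound 1 (beyond the scatter) and the change is the same. Compound 4 is therefore estimated at -2.3, likely between -2.75 and -1.85.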

Compound 4, distribution coefficient: -2.32
Estimate against measurement, compound 4: 0.02 log units above; the measured number falls inside the stated range.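

In this assay, putting pent-4-yn-1-yl in place of (but-3-yn-1-yl)oxy on a saturated chain carbon bound to an aromatic nitrogen gave a number 0.40 log units higher from compound 3 to compound 4 (beyond the scatter) and, on the other core, a number 0.42 log units higher from compound 2 to compound 1 (beyond the scatter) as the earlier step. The change therefore went the same way on both cores, with steps of similar size, but these two pairs show only that it carried over here and do not establish a rule for any further core or any other group. Nothing shown bears on what lies behind the step on either core.

The compounds shown leave open how a longer chain, an amine or a carboxylic acid would read in place of pent-4-yn-1-yl on a saturated chain carbon bound to an aromatic nitrogen. They also leave open whether the step would keep its size on a third core.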